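The compounds below may be only part of what the source reports. "The series", "measured", "known", "first", "only" and "open" are said of these compounds alone.

Three compounds of the series carry numbers in an ADME assay on Vero cells (Chlorocebus sabaeus) for cytotoxicity, read by MTT assay, with a stated time of 48 h; a lower number here means a stronger inhibitor, a higher number a weaker inhibitor. Compound 1 `CN(Cc1ccc2c(c1)OCCO2)c1nc(=O)c2cc(C(F)(F)F)cc([N+](=O)[O-])c2o1` gives 9.27 ug/mL. Compound 2 `O=c1cc(N2CCN(CC3CCCCC3)CC2)oc2c([N+](=O)[O-])cc(C(F)(F)F)cc12` gives 10.6 ug/mL. Compound 3 `CC1CN(c2nc(=O)c3cc(C(F)(F)F)cc([N+](=O)[O-])c3o2)CCN1CC1CCCCC1` gives 10.9 ug/mL, the highest of the three numbers, yet its gaps to compound 2 and to compound 1 both lie within the usual scatter, so no order among the three is claimed. Compound 4 `O=c1nc(N2CCN(CC3CCCCC3)CC2)oc2c([N+](=O)[O-])cc(C(F)(F)F)cc12` has not yet been measured in this assay. Relative to compound 3 it shows a single change: hydrogen in place of methyl on a saturated ring carbon. Going by the values given here, no step between measured compounds that differ in one place is available, and the three known numbers sit close together. The step from compound 3 to compound 4 is expected to be none beyond the scatter, a 1.0-fold lower number from compound 3 to compound 4 (0.02 log units; within the scatter). Compound 4 is therefore estimated at 10.5 ug/mL, with a range from 5.5 ug/mL to 20 ug/mL.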

Compound 4, half-maximal inhibitory concentration: 52.1 ug/mL
The estimate for compound 4 lay 5.0-fold (0.70 log units) below the measured number, outside the stated range (above it).
By their numbers in this assay, from the lowest: compounds 1, 2 and 3 (each within the scatter of the next); then compound 4.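

In this assay, the saturated ring carbon next to the ring nitrogen is not a silent position: hydrogen in place of methyl gives a 4.8-fold higher number from compound 3 to compound 4 (0.68 log units; beyond the scatter) and takes the series clear of the scatter. Going by these compounds alone, the earlier compounds offered no step of this kind, so this is the only single-place reading of the position so far. No measurement shown bears on the reason for the step.

From the compounds shown here alone, whether an ethyl group, a hydroxymethyl group or an amine on this carbon would read like methyl or like hydrogen stays open. The direction of any such step also rests on this one pair.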